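The source may report more compounds than this note shows. Statements on the series, on what has been measured and on what is new or still open speak of the compounds shown alone.

In a functional assay on SW-620 cells (Homo sapiens) for cytotoxicity, read by sulforhodamine B assay, with a stated time of 48 h (a lower number here means a stronger inhibitor, a higher number a weaker inhibitor), compound 2 (`C[C@H]1CC[C@@H]2[C@@H](OC(=O)[C@]23CC(c2ccc(O)cc2)=NO3)[C@]2(C)C(=O)C=C[C@@]12O`) gives the highest of three numbers at 89000 nM against compound 1 (`C[C@H]1CC[C@@H]2[C@@H](OC(=O)[C@]23CC(c2ccc(N(C)C)cc2)=NO3)[C@]2(C)C(=O)C=C[C@@]12O`) at 5100 nM and compound 3 (`C[C@H]1CC[C@@H]2[C@@H](OC(=O)[C@]23CC(c2ccccc2[N+](=O)[O-])=NO3)[C@]2(C)C(=O)C=C[C@@]12O`) at 40000 nM. Compound 4 (`C[C@H]1CC[C@@H]2[C@@H](OC(=O)[C@]23CC(c2cccc([N+](=O)[O-])c2)=NO3)[C@]2(C)C(=O)C=C[C@@]12O`) has 3-nitrophenyl in place of 4-hydroxyphenyl on a carbon with a double bond to nitrogen. The closest measured step, a 2.2-fold lower number from compound 2 to compound 3 (0.35 log units; beyond the scatter), is modest and puts 2-nitrophenyl in that same place. The larger 17-fold higher number from compound 1 to compound 2 (1.24 log units; beyond the scatter) and the modest 7.8-fold higher number from compound 1 to compound 3 (0.89 log units; beyond the scatter) both start from 4-(dimethylamino)phenyl and bear on it less directly. A modest step to a lower number is therefore expected in this assay, although 3-nitrophenyl itself remains unmeasured. The expected change is a 2.5-fold lower number from compound 2 to compound 4 (0.41 log units; beyond the scatter). For compound 4 the estimated value is 35000 nM, with an expected range from 12000 nM to 80000 nM.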

Compound 4, half-maximal inhibitory concentration: 49000 nM
Beside the measured number, compound 4's estimate is 1.4-fold (0.15 log units) below it; measured number inside the range.
By their numbers in this assay, from the lowest: compound 1; then compounds 3, 4 and 2 (each within the scatter of the next, the first and the last beyond it).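

In this assay, 3-nitrophenyl on the carbon with a double bond to nitrogen cannot be told apart from 4-hydroxyphenyl (a 1.8-fold lower number from compound 2 to compound 4 (0.26 log units; within the scatter)) or from 2-nitrophenyl (a 1.2-fold higher number from compound 3 to compound 4 (0.09 log units; within the scatter)). Only 4-(dimethylamino)phenyl stands clearly apart from it (a 9.6-fold higher number from compound 1 to compound 4 (0.98 log units; beyond the scatter)), so the two nitrophenyl groups give no resolved difference at this position. No evidence is available to explain these results. Going by these compounds, it remains open how a primary amine, a carboxylic acid or a longer alkyl chain on the phenyl ring would compare with the dimethylamino group.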